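Swapping cyclohexyl for methyl in compound 2

The compounds below may be only part of what the source reports. "The series", "measured", "known", "first", "only" and "open" are said of these compounds alone.

Compound 1 `COc1ccc(-c2c(C)nc3c(N4CC[C@@H](NS(C)(=O)=O)C4)cc(C)nn23)cc1OC` | > 95%
Compound 2 `COc1ccc(-c2c(C)nc3c(N4CCN(C(=O)C5CCCCC5)CC4)cc(C)nn23)cc1OC` | > 95%

In an ADME assay on microsomes from liver (Mus musculus) for metabolic stability, read by LC-MS, with NADPH named in the record, with a stated time of 60 min, tested at 1 uM, in the absence of a further agent (a lower number here means that less of the compound is left, a higher number that more of the compound is left), compound 2 gives > 95% as a limit of the assay and not as a number. Compound 2 therefore has no exact value to start from. Among the compounds with values here, the picture so far is short: the limit of > 95% in this assay, at which 2 of the 2 values shown sit, and no step between measured compounds can be read from it.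

Compound 3 `COc1ccc(-c2c(C)nc3c(N4CCN(C(C)=O)CC4)cc(C)nn23)cc1OC` has not yet been measured. It carries methyl in place of cyclohexyl on a carbonyl carbon and the same difference reads cyclohexylcarbonyl to acetyl.

Within the data shown here, with no measured step to lean on, the expectation rests on compound 2 itself, whose > 95% is a limit. The expected step of a number no higher from compound 2 to compound 3 (the limit leaves the size open) stays within the usual scatter of this assay and has no clear direction. Compound 3 is estimated at 95% with an expected range from 82% to 100% for this measurement.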

Compound 3, percent of the compound remaining: > 95%
Compound 3 ended at the assay's limit; the forecaster's own chance of this, stated with the estimate: 60%; the middle value lies on the limit itself.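

No step can be read from compound 2 to compound 3 or from compound 1 to compound 3, because all three compounds sit at the same limit of the assay, not at exact numbers: the limit of > 95% in this assay, at which 3 of the 3 values shown sit.

The compounds shown leave open whether any change to these groups would bring a compound off that limit and give a readable difference.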